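The compounds below may be only part of what the source reports. "The series", "measured", "known", "first", "only" and "open" are said of these compounds alone.

Compound 3, with the structure `COc1ccc(C(=O)O[C@H]2C(=O)OCC2(C)C)cc1`, gives 13700 nM in an assay on isolated protein for inhibition of fatty acid synthase (Mus musculus), read by spectrophotometry, using NADPH, with stated times of 30 min and 3 min, in the presence of a further agent that is not named here (a higher number here means a weaker inhibitor, a lower number a stronger inhibitor), the smallest of the three numbers shown, though neither of the others lies beyond the scatter of it. Compound 1, with the structure `CCCCCCCC(=O)O[C@H]1C(=O)OCC1(C)C`, gives 20800 nM in this assay, and compound 2, with the structure `CC1(C)COC(=O)[C@@H]1OC(=O)c1ccccc1`, gives 23000 nM. Within the data shown here, the only single-site step on record is a 1.7-fold lower number from compound 2 to compound 3 (0.23 log units; within the scatter). Compound 4, with the structure `CCCCc1ccc(C(=O)O[C@H]2C(=O)OCC2(C)C)cc1`, carries the change butyl in place of methoxy on an aromatic carbon relative to compound 3. Among the measured compounds shown here, no measured step swaps methoxy for butyl, and the one step touching that aromatic carbon stayed within the scatter, so no step beyond the scatter is expected. The estimate for compound 4 in this assay is 11000 nM, between 3500 nM and 35000 nM, an expected step of a 1.2-fold lower number from compound 3 to compound 4 (0.10 log units; within the scatter).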

Compound 4, half-maximal inhibitory concentration: 27700 nM
Compound 4: the middle estimate sits 2.5-fold (0.40 log units) below what was measured, and the stated range covers the measured number.
By their numbers in this assay, from the lowest: compounds 3, 1, 2 and 4 (each within the scatter of the next, the first and the last beyond it).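

In this assay, among these compounds, butyl in place of methoxy on this aromatic carbon gives a 2.0-fold higher number from compound 3 to compound 4 (0.31 log units; beyond the scatter), the first step beyond the scatter, though a modest one. Butyl in place of hydrogen at the same carbon gives only a 1.2-fold higher number from compound 2 to compound 4 (0.08 log units; within the scatter), so butyl shows no clear change from the unsubstituted ring, and the gap appears only against methoxy. Nothing available explains this difference between the two groups.

Still open, as far as these compounds go, is whether an amine, a carboxylic acid or a chain longer than butyl on this carbon would shift the number in either direction. A hydroxyl group there could also show whether the oxygen of methoxy matters.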